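From 4-nitrophenyl to 3,4-difluorophenyl on the shared core

The source may report more compounds than this note shows. Statements on the series, on what has been measured and on what is new or still open speak of the compounds shown alone.

For the measured compounds named here, in a functional assay on NCI-H460 cells (Homo sapiens) for inhibition, with a stated time of 72 h (on this read-out lower numbers stand for stronger inhibition and higher numbers for weaker inhibition), compound 2 (`COc1ccc(S(=O)(=O)N2CCc3cccc(-c4ccc([N+](=O)[O-])cc4)c32)cc1`) gives 53.1 nM and holds the lower of the two numbers so far, while compound 1 (`COc1ccc(S(=O)(=O)N2CCc3cccc(-c4ccc(F)nc4)c32)cc1`) gives 135 nM as its nearest neighbour. Compound 3 (`COc1ccc(S(=O)(=O)N2CCc3cccc(-c4ccc(F)c(F)c4)c32)cc1`) carries 3,4-difluorophenyl in place of 4-nitrophenyl on an aromatic carbon. Going by the values given here, the only measured step at this carbon (a 2.5-fold lower number from compound 1 to compound 2 (0.41 log units; beyond the scatter)) is modest, and compound 1 also carries fluorine there. A modest rise of similar size is therefore expected (a 2.3-fold higher number from compound 2 to compound 3 (0.35 log units; beyond the scatter)) in this assay for this change. Compound 3 is estimated at 120 nM with an expected range of 40 nM to 350 nM on this read-out.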

Compound 3, half-maximal inhibitory concentration: 46 nM
For compound 3 the middle estimate is 2.6-fold (0.42 log units) above the measured one, and the stated range covers the measured number.
By their numbers in this assay, from the lowest: compounds 3 and 2 (each within the scatter of the next); then compound 1.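

In this assay 3,4-difluorophenyl and 4-nitrophenyl are not separated at this aromatic carbon, with a 1.2-fold lower number from compound 2 to compound 3 (0.06 log units; within the scatter) for a group of 0 hydrogen-bond acceptors in place of one of 2. Replacing 6-fluoropyridin-3-yl with 3,4-difluorophenyl gives a 2.9-fold lower number from compound 1 to compound 3 (0.47 log units; beyond the scatter) and so shows a second modest step away from that group. No supporting data account for either result. Still open, going by these compounds, is whether a phenyl group with a single fluorine matches 3,4-difluorophenyl. Also open, on these data alone, is whether an amine or a carboxylic acid on the same carbon stays in this range.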